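A few compounds are considered here, and "the series" means these few. Any claim that something is new, unique, unknown or untested is made for them only; others in the source may bear on it.

In a functional assay on A549 cells (Homo sapiens) for cytotoxicity, read by MTT assay, with a stated time of 72 h (on this read-out lower numbers stand for stronger inhibition and higher numbers for weaker inhibition), compound 1 (`COc1cc(O)cc2c1OC[C@H](Cc1ccc(O)cc1)C2`) gives > 100000 nM, which is a limit of the assay and not a number. Compound 2 (`COc1ccc(C(=O)CCc2c(OC)cc(O)cc2OC)cc1`) gives > 100000 nM, and this too is a limit rather than a number. Compound 2 thus stands with compound 1 at the limit of > 100000 nM in this assay, at which 2 of the 2 values shown sit. Compound 3 (`COc1cc(O)cc(OC)c1CCC(=O)c1ccc(O)cc1`) has not yet been measured. It differs from compound 2 by one change, hydrogen in place of methyl on an oxygen on an aromatic ring: methoxy to hydroxy, with hydrogen in place of methyl on an oxygen on an aromatic ring. For the measured compounds named here, no measured step is available to size this change. In this assay no large step is expected, at most a small one toward stronger inhibition, and the read-out may well remain at the limit. The estimated at least 1.2-fold lower number from compound 2 to compound 3 (0.09 log units; that floor lies within the scatter) is correspondingly modest. For compound 3 the expected value is 80000 nM, within an estimated range of 20000 nM to 200000 nM.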

Compound 3, half-maximal inhibitory concentration: 42900 nM
Beside the measured number, compound 3's estimate is 1.9-fold (0.27 log units) above it; the range from low to high includes it.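

In this assay the change from methoxy to hydroxy, with hydrogen in place of methyl on an oxygen on an aromatic ring, gives an at least 2.3-fold lower number from compound 2 to compound 3 (0.36 log units; beyond the scatter) and so yields the only true number among the compounds shown. Compound 3 gives 42900 nM and thereby shows that this position responds to the change, which brings the read-out inside the range of the assay. From the compounds shown here alone, the full size of the step stays unknown, since its starting point is a limit and not a number: the limit of > 100000 nM in this assay, at which 2 of the 3 values shown sit.

Going by these compounds, whether the methoxy groups that remain in compound 3 respond in the same way stays open. So does the question of whether an amine or a carboxylic acid at this place would move the number further, and a single step supports no wider pattern.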